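Adding a second fluoro group to compound 2

The source may report more compounds than this note shows. Statements on the series, on what has been measured and on what is new or still open speak of the compounds shown alone.

Within the data shown here, in a functional assay on NCI-H1993 cells (Homo sapiens) for inhibition, read by CCK-8 assay, with a stated time of 72 h (on this read-out higher numbers stand for weaker inhibition and lower numbers for stronger inhibition), compound 2 (`CC(c1cc2cccnc2cc1F)n1cnc2ncc(-c3cnc4ccccc4c3)nc21`) gives 109 nM as the higher of the two numbers so far. Compound 1 (`CC(c1c(F)cc2ncccc2c1F)n1cnc2ncc(-c3cnn(C)c3)nc21`) gives 35.5 nM on the same read-out, a gap beyond the scatter, but these two compounds differ in more than one place, so the gap belongs to no single change. Compound 3 (`CC(c1c(F)cc2ncccc2c1F)n1cnc2ncc(-c3cnc4ccccc4c3)nc21`) carries fluoro in place of hydrogen on an aromatic carbon of compound 2 (fluoro in place of hydrogen on an aromatic carbon) and so shares both fluoro groups with compound 1. Among the measured compounds shown here, no measured pair isolates this change. A modest move toward stronger inhibition in this assay is expected, possibly no larger than the scatter. The estimated change is a 1.7-fold lower number from compound 2 to compound 3 (0.22 log units; within the scatter) in size. Compound 3 is estimated at 65 nM with 22 nM to 190 nM as the expected range.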

Compound 3, half-maximal inhibitory concentration: 46.1 nM
Compound 3: the middle estimate sits 1.4-fold (0.15 log units) above what was measured; the measured number falls inside the stated range.
By their numbers in this assay, from the lowest: compounds 1 and 3 (each within the scatter of the next); then compound 2.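

In this assay, among these compounds, fluoro in place of hydrogen on an aromatic carbon, ortho to a large group and meta to a fluoro group, gives a 2.4-fold lower number from compound 2 to compound 3 (0.37 log units; beyond the scatter), the first single-change reading at this position. With both fluoro groups in place, quinolin-3-yl in place of 1-methyl-1H-pyrazol-4-yl gives a 1.3-fold higher number from compound 1 to compound 3 (0.11 log units; within the scatter), so the two groups cannot be told apart on this read-out. No data at hand bear on the reason for the fluoro step.

From the compounds shown here alone, the fluoro step is read only with quinolin-3-yl on the shared core, so its size alongside 1-methyl-1H-pyrazol-4-yl stays open. Also open is how chloro or methoxy on the same aromatic carbon would compare with fluoro, since the compounds shown carry only hydrogen or fluoro there.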